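Lengthening a Fatty Amide Chain on a Shared Core

A few compounds are considered here, and "the series" means these few. Any claim that something is new, unique, unknown or untested is made for them only; others in the source may bear on it.

Compound 1 `CCCCCC[C@@H](O)C/C=C\CCCCCCCCSCCC(=O)NCc1ccc(O)c(OC)c1`: > 10000 nM
Compound 2 `CCCCCCCCCCCCCCCC(=O)NCc1ccc(O)c(OC)c1`: > 10000 nM
Compound 3 `CCCCCCCCCCCCCCCCOC(=O)CSC[C@H](N)C(=O)NCc1ccc(O)c(OC)c1`: 1400 nM

All three compounds share one core and were tested in an assay on HEK293 cells for antagonist activity at transient receptor potential cation channel subfamily V member 2 (Rattus norvegicus), read by fluorescence and calcium flux, with a stated time of 5 min; on this read-out lower numbers stand for stronger inhibition and higher numbers for weaker inhibition. For compound 2 the value is a limit of the assay, not a number. For compound 1 the value is likewise a limit. Compound 2 thus sits at the limit of > 10000 nM in this assay, at which 2 of the 3 values shown sit. Only compound 3 gives a measured number in this assay.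

Compound 4 `CCCCCCCCCCCCCCCCCC(=O)NCc1ccc(O)c(OC)c1` differs from compound 2 by ethyl in place of hydrogen on a saturated chain carbon, ten or more bonds along the chain from a carbonyl carbon. Among the measured compounds shown here, no measured pair shows what this change does. Because compound 2 gives > 10000 nM, compound 4 is expected to remain near that limit. The expected step is a step that the limit leaves unreadable from compound 2 to compound 4, which means no change beyond the usual scatter. For compound 4 the estimate is 15000 nM, with a range from 5000 nM to 50000 nM.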

Compound 4, half-maximal inhibitory concentration: > 10000 nM
Compound 4 ended at the assay's limit; the forecaster's own chance of this, stated with the estimate: 75%; the middle value does not contradict the limit.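

Among the compounds shown here, compound 2 and compound 4 both sit at a limit of the assay rather than at a number, so no step between them can be read. On these data alone, what lengthening this fatty amide chain does in this assay stays open.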